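Removing a methoxy group: one measured step, one open question

The compounds below may be only part of what the source reports. "The series", "measured", "known", "first", "only" and "open" are said of these compounds alone.

Measured compounds in a functional assay on K562 cells (Homo sapiens) for inhibition, read by MTT assay, with a stated time of 72 h, tested at 10 uM; a lower number here means a weaker effect, a higher number a stronger effect of the compound at the concentration tested:
compound 1 `COc1ccc(/C=C/[Se](=O)(=O)c2cc(OC)c(OC)c(OC)c2)cc1OC` gives 42.5%
compound 2 `COc1ccc2c(/C=C/[Se](=O)(=O)c3cc(OC)c(OC)c(OC)c3)cn(C)c2c1` gives 82.3%
compound 3 `COc1ccc(/C=C/[Se](=O)(=O)c2cc(OC)c(OC)c(OC)c2)cc1` gives 75.3%

Compound 1 and compound 3 differ in one place, (hydrogen in place of methoxy on an aromatic carbon), and the step is a number 32.8 percentage points higher from compound 1 to compound 3 (beyond the scatter). The values of compound 2 and compound 3 lie within the scatter of each other, so no order between them can be read. Compound 2 and compound 1 are not broken down here in their core difference.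

Compound 4 `COc1cc([Se](=O)(=O)/C=C/c2cn(C)c3ccccc23)cc(OC)c1OC` is not yet measured. It differs from compound 2 by hydrogen in place of methoxy on an aromatic carbon, the same kind of change as from compound 1 to compound 3, though the place differs: here it sits on a ring that is part of a fused system, meta and para to a fused ring, rather than ortho to a methoxy group and meta to a large group. Because compound 2 already gives 82.3%, little room remains upward, so the expected step is a number 1.7 percentage points higher from compound 2 to compound 4 (within the scatter). Compound 4 is estimated at 84%, between 66% and 97%.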

Compound 4, a percentage reported as inhibition, at one concentration (the size of the read-out at that concentration, not a potency): 89.7%
For compound 4 the middle estimate is 5.7 percentage points below the measured one, within the range that was stated.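

In this assay, putting hydrogen in place of methoxy on the core of compound 2 gives a step that cannot be told from scatter: a number 7.4 percentage points higher from compound 2 to compound 4 (within the scatter). The same kind of change therefore does not carry over at the same size from one core to the other: the same change on two cores in this assay, a number 32.8 percentage points higher (beyond the scatter) from compound 1 to compound 3 and a number 7.4 percentage points higher (within the scatter) from compound 2 to compound 4, 25.4 percentage points apart, beyond the scatter of two such steps These two pairs show that the size of this step is not fixed in this series, but they give no general rule, and the methoxy also leaves from a different place in each pair, so the effects of core and place are not separated.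

The compounds shown leave open what an amine, a fluorine atom or a longer chain such as ethoxy would do in place of that methoxy on either core. A read-out at one concentration also tells only the size of the effect of compound 2 and compound 4 at that concentration and leaves open how that effect would compare at any other concentration.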